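The source may report more compounds than this note shows. Statements on the series, on what has been measured and on what is new or still open speak of the compounds shown alone.

Measured compounds in the series:

Compound 1, `CC(C)(C)C(=O)OCC1(CO)C/C(=C\CCCCCCCCCCCO)C(=O)O1`: 0.65 ug/mL
Compound 2, `COCCCCCCCCCCCCCCC/C=C1\CC(CO)(COC(=O)C(C)(C)C)OC1=O`: 4.26 ug/mL
Compound 3, `COCCCCCCCCCCC/C=C1\CC(CO)(COC(=O)C(C)(C)C)OC1=O`: 0.701 ug/mL

In a functional assay on CCRF-CEM cells (Homo sapiens) for antiproliferative activity (on this read-out lower numbers stand for stronger inhibition of growth and higher numbers for weaker inhibition of growth), compound 1 gives the lowest of the three numbers; compound 3 lies nearest, and the pair differ only within the scatter, so nothing separates them on this read-out. Compound 2 stands furthest from compound 1.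

Compound 4, `CC(C)(C)C(=O)OCCCCCCCCCCCCCCC/C=C1\CC(CO)(COC(=O)C(C)(C)C)OC1=O`, is not yet measured in this assay. Relative to compound 1 the change is 4-(((tert-butyl)carbonyl)oxy)butyl in place of hydroxy on a saturated chain carbon, ten or more bonds along the chain from a double-bonded chain carbon.

The bearing steps are those that lengthen the chain terminus. The step of a 6.6-fold higher number from compound 1 to compound 2 (0.82 log units; beyond the scatter) shows that placing 4-methoxybutyl at this position raises the number modestly. The reverse comparison, a 6.1-fold lower number from compound 2 to compound 3 (0.78 log units; beyond the scatter), shows that trimming the terminus back to methoxy returns the number to the range of compound 1, while the step of a 1.1-fold higher number from compound 1 to compound 3 (0.03 log units; within the scatter) shows that hydroxy and methoxy at the terminus are not distinguished. Compound 4 carries a still larger terminal group than compound 2, so a rise in the number of at least the size seen from compound 1 to compound 2 is the expected outcome.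

Compound 4 is therefore estimated at 5 ug/mL, within the range 1.8 ug/mL to 14 ug/mL, corresponding to an expected step of a 7.7-fold higher number from compound 1 to compound 4 (0.89 log units; beyond the scatter).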

Compound 4, concentration for 50% growth inhibition: > 10 ug/mL
Compound 4: a limit, no number (the forecaster's own chance of this, stated with the estimate: 5%); middle value at least 2.0-fold (0.30 log units) from the limit.
By their numbers in this assay, from the lowest: compounds 1 and 3 (each within the scatter of the next); then compound 2. At a limit, above all of these: compound 4.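

In this assay compound 4 reads as a limit of the assay and not as a number: the limit of > 10 ug/mL in this assay, at which 1 of the 4 values shown sits.

Exchanging only the group on the terminal oxygen, with (tert-butyl)carbonyl in place of methyl on an oxygen on a saturated carbon, still gives an at least 2.3-fold higher number from compound 2 to compound 4 (0.37 log units; beyond the scatter), so at this chain length the number responds to the end group as well as to the extension seen earlier. Set against the two compounds with the shorter substituents at this place, the change gives an at least 15-fold higher number from compound 1 to compound 4 (1.18 log units; beyond the scatter) and an at least 14-fold higher number from compound 3 to compound 4 (1.15 log units; beyond the scatter), the only steps in the series rated large, and these show that the loss of growth inhibition in this assay on going to 4-(((tert-butyl)carbonyl)oxy)butyl exceeds anything compound 2 had indicated.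

From the compounds shown here alone, how far compound 4 lies past its limit stays unknown, so all three steps give only a lower bound on the true size. Also open, going by these compounds, is how an amine or a carboxylic acid would read at this same place on the chain, and whether either would stay in the range of compound 1.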